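The compounds below may be only part of what the source reports. "The series", "measured", "known", "first", "only" and "open" are said of these compounds alone.

Working notes on the series, all read in a functional assay on HCC827 cells (Homo sapiens) for cytotoxicity, read by MTT assay, with a stated time of 72 h; a lower number here means a stronger inhibitor, a higher number a weaker inhibitor. Compound 1 (`Cc1cc(C)cc(-n2c(Nc3ccccc3)nc3cnc(Nc4ccc(N5CCN(C)CC5)cc4)nc32)c1`) gives 1 nM. Compound 2 (`CC(=O)Nc1ccc(Nc2ncc3nc(Nc4ccccc4)n(C4CCCC4)c3n2)cc1`) gives 0.47 nM. Compound 3 (`C#Cc1cccc(Nc2nc3cnc(Nc4ccc(N5CCN(C)CC5)cc4)nc3n2C2CCCC2)c1`) gives < 0.01 nM, which is a limit of the assay and not a number. Compound 3 therefore stands at the limit of < 0.01 nM in this assay, at which 1 of the 3 values shown sits.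

Compound 4 (`CN1CCN(c2ccc(Nc3ncc4nc(Nc5cccc(Cl)c5)n(C5CCCC5)c4n3)cc2)CC1`) is next, and its difference from compound 3 is chloro in place of ethynyl on an aromatic carbon. In words, this is chloro in place of ethynyl on an aromatic carbon, taking 3-ethynylphenyl to 3-chlorophenyl. Going by the values given here, no measured pair isolates this change, so the size of the step in this assay remains an expectation. Compound 3 sits at the limit < 0.01 nM, so any number reported for compound 4 would be expected on the weaker side. A moderate step toward a weaker inhibitor is expected, estimated as an at least 10-fold higher number from compound 3 to compound 4 (1.00 log units; beyond the scatter). For compound 4 the estimated value is 0.1 nM, with an expected range of 0.01 nM to 1 nM.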

Compound 4, half-maximal inhibitory concentration: < 0.01 nM
Compound 4: a limit, no number; the forecaster's own chance of this, stated with the estimate: 20%; middle value at least 10-fold (1.00 log units) from the limit.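

Compound 3 and compound 4 are both limits of the assay and not numbers, so no step can be read between them: the limit of < 0.01 nM in this assay, at which 2 of the 4 values shown sit.

The compounds shown leave open whether chloro in place of ethynyl changes the read-out in this assay at all, and by how much.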